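Amide aryl variation in the shared-core series

The compounds below may be only part of what the source reports. "The series", "measured", "known", "first", "only" and "open" are said of these compounds alone.

Measured so far, in a functional assay on MDA-MB-231 cells (Homo sapiens) for antiproliferative activity, read by MTT assay, with a stated time of 72 h; on this read-out higher numbers stand for weaker inhibition and lower numbers for stronger inhibition:
- compound 1 `O=C(CCc1cccc2c1B(O)OC2)Nc1nccs1` gives only the assay limit > 100000 nM.
- compound 2 `O=C(CCc1cccc2c1B(O)OC2)Nc1ccc(F)cc1` gives 440 nM.
- compound 3 `O=C(CCc1cccc2c1B(O)OC2)Nc1cccc(I)c1` gives 5300 nM.

Compound 3 stands highest of the two numbers shown; its nearest neighbour is compound 2, with a 12-fold higher number from compound 2 to compound 3 (1.08 log units; beyond the scatter). Against compound 1 the step is an at least 18-fold lower number from compound 1 to compound 3 (1.27 log units; beyond the scatter). Compound 1 itself sits only at the limit (the limit of > 100000 nM in this assay, at which 1 of the 3 values shown sits), so that step is a lower bound. The remaining step, an at least 220-fold lower number from compound 1 to compound 2 (2.35 log units; beyond the scatter), is likewise bounded.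

Compound 4 `CSc1cccc(-c2cccc(NC(=O)CCc3cccc4c3B(O)OC4)c2)c1` differs from compound 3 in one place: 3-(methylsulfanyl)phenyl in place of iodo on an aromatic carbon. Among the compounds with values here, no measured step changes a substituent on the six-membered aromatic ring of carbon only; all three measured steps exchange the whole ring on the amide-type nitrogen, and both that end at compound 3 are large. They show that this end of the molecule moves the number by a large amount, but the direction for the present change cannot be read from them. Compound 4 is therefore expected to lie near compound 3, with a 2.1-fold lower number from compound 3 to compound 4 (0.33 log units; beyond the scatter) as the central guess and a wide range. The estimate for compound 4 is 2500 nM, from 300 nM to 20000 nM.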

Compound 4, half-maximal inhibitory concentration: 150 nM
Compound 4: the middle estimate sits 17-fold (1.22 log units) above what was measured; measured number below the stated range.
By their numbers in this assay, from the lowest: compound 4; then compound 2; then compound 3. At a limit, above all of these: compound 1.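

Within the data shown here, this is the first step that keeps the ring on the amide-type nitrogen and changes only a substituent on it, and in this assay it gives a 35-fold lower number from compound 3 to compound 4 (1.55 log units; beyond the scatter) as iodo gives way to 3-(methylsulfanyl)phenyl. The place meta to a large group on that ring therefore accepts a group of 8 heavy atoms, carrying a further six-membered aromatic ring of carbon only, in place of 1 iodine, and the number falls rather than rises on this exchange. Nothing on hand bears on why this step runs in this direction or has this size.

Among these compounds, the single step changes the added ring and the methylsulfanyl group together, so a plain phenyl, or a phenyl carrying methoxy, an amine or a carboxylic acid, at the same place would be needed to tell which part goes with the lower number. Also open, as far as these compounds go, is whether the gain holds with other changes to the molecule, such as a longer chain between the shared core and the amide carbonyl.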